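A few compounds are considered here, and "the series" means these few. Any claim that something is new, unique, unknown or untested is made for them only; others in the source may bear on it.

Three compounds that share one core and differ only in the group on an aromatic carbon have been tested in a functional assay on U2OS cells (Homo sapiens) for antiproliferative activity, read by MTT assay, with a stated time of 72 h; a lower number here means a stronger inhibitor, a higher number a weaker inhibitor. Compound 1 `O=C(C1=C(Nc2ccccc2)C(=O)N(CCCn2ccnc2)C1c1ccc(Br)cc1)c1ccccc1` carries hydrogen at that place and gives 25700 nM. Compound 2 `Cc1ccc(NC2=C(C(=O)c3ccccc3)C(c3ccc(Br)cc3)N(CCCn3ccnc3)C2=O)cc1` carries methyl there and gives 24100 nM. Compound 3 `CCOc1ccc(NC2=C(C(=O)c3ccccc3)C(c3ccc(Br)cc3)N(CCCn3ccnc3)C2=O)cc1` carries ethoxy there and gives 26200 nM, which stands highest of the three numbers as they are written, although every pairwise difference is within the scatter: a 1.1-fold lower number from compound 1 to compound 2 (0.03 log units; within the scatter), a 1.0-fold higher number from compound 1 to compound 3 (0.01 log units; within the scatter) and a 1.1-fold higher number from compound 2 to compound 3 (0.04 log units; within the scatter). Compound 4 `O=C(C1=C(Nc2ccc(I)cc2)C(=O)N(CCCn2ccnc2)C1c1ccc(Br)cc1)c1ccccc1` is reached from compound 3 by the change (iodo in place of ethoxy on an aromatic carbon). Among the compounds with values here, no measured step involves iodo, so the bearing of the known steps is indirect; still, all three swaps at this same place left this assay unchanged beyond the scatter, so no shift beyond the scatter is expected from compound 3 to compound 4, namely a 1.0-fold lower number from compound 3 to compound 4 (0.02 log units; within the scatter). Compound 4 is therefore estimated at 25000 nM, with a range from 11000 nM to 55000 nM.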

Compound 4, half-maximal inhibitory concentration: 12000 nM
Compound 4: middle estimate off by 2.1-fold (0.32 log units), on the high side; low and high end bracket the measured number.
By their numbers in this assay, from the lowest: compounds 4, 2, 1 and 3 (each within the scatter of the next, the first and the last beyond it).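

Of the four groups tried at this position, iodo is the only one that moves the result in this assay beyond the scatter: the step gives a 2.2-fold lower number from compound 3 to compound 4 (0.34 log units; beyond the scatter) and a 2.1-fold lower number from compound 1 to compound 4 (0.33 log units; beyond the scatter), both modest, while a 2.0-fold lower number from compound 2 to compound 4 (0.30 log units; within the scatter) only reaches the edge of the scatter without passing it. The position is therefore not entirely indifferent to what sits there, even though hydrogen, methyl and ethoxy could not be told apart. The data offer no measurement that would explain the shift.

On these data alone, it remains open whether the shift belongs to iodo alone or would also appear with fluoro, chloro or bromo at this carbon. An amine or a carboxylic acid in the same place could show whether this position can give a larger change than the modest one seen here.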